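This account rests on a few compounds, and the source may have more. Where it says the series, first, only, none or still open, it means among the compounds named here.

Compound 2 `CC(=O)N1CCc2c(c(-c3ccc(I)cc3)nn2CC(O)CN2CCC(n3c(O)nc4ccccc43)CC2)C1` gives 120 nM in an assay on isolated protein for inhibition of cathepsin S (Homo sapiens); a higher number here means a weaker inhibitor, a lower number a stronger inhibitor. Among the three measured compounds it stands second highest, with compound 1 `CC(=O)N1CCc2c(c(-c3ccc(OC(F)(F)F)cc3)nn2CC(O)CN2CCC(n3c(O)nc4ccccc43)CC2)C1` at 130 nM and compound 3 `CC(=O)N1CCc2c(c(-c3ccc(C(F)(F)F)cc3)nn2CC(O)CN2CCC(n3c(O)nc4ccccc43)CC2)C1` at 100 nM; the steps of a 1.1-fold lower number from compound 1 to compound 2 (0.03 log units; within the scatter), a 1.3-fold lower number from compound 1 to compound 3 (0.11 log units; within the scatter) and a 1.2-fold lower number from compound 2 to compound 3 (0.08 log units; within the scatter) all lie within the scatter. Compound 4 `CC(=O)N1CCc2c(c(-c3ccc(I)cc3)nn2CC(O)CN2CCC(n3c(O)nc4ccc(F)cc43)CC2)C1` differs from compound 2 by fluoro in place of hydrogen on an aromatic carbon, so the 2-hydroxy-1H-benzimidazol-1-yl group becomes 6-fluoro-2-hydroxy-1H-benzimidazol-1-yl. For the measured compounds named here, none of the measured steps touches that part of the shared core; each of them exchanges one group for another elsewhere in the structure, and each was small. No step beyond the scatter is therefore expected from compound 2 to compound 4, no change at the digits printed from compound 2 to compound 4 (within the scatter). Compound 4 is expected to give 120 nM in this assay, with a range from 50 nM to 300 nM.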

Compound 4, half-maximal inhibitory concentration: 230 nM
Compound 4: middle estimate off by 1.9-fold (0.28 log units), on the low side, within the range that was stated.
By their numbers in this assay, from the lowest: compounds 3, 2, 1 and 4 (each within the scatter of the next, the first and the last beyond it).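

For the compounds shown here, the step of a 1.9-fold higher number from compound 2 to compound 4 (0.28 log units; within the scatter) in this assay is the first look at the 2-hydroxy-1H-benzimidazol-1-yl group, which the earlier steps left untouched. It stays within the scatter, so a fluoro at this position of the six-membered aromatic ring is tolerated without a change that can be told from repeat measurement. Nothing available explains the numbers at this position. Going by these compounds, whether a larger group here, such as methoxy, chloro or an amine, would shift the number remains open. So does the effect of a fluoro on the ring's other carbons.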